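The source may report more compounds than this note shows. Statements on the series, on what has been measured and on what is new or still open speak of the compounds shown alone.

Three compounds share one core and differ only in the group on one aromatic carbon. Compound 1 `O=c1[nH]c(=O)n([C@H]2C[C@H](O)[C@@H](CO)O2)cc1[N+](=O)[O-]` carries a nitro group there, and in an ADME assay on L1210/0 cells (Mus musculus) for cytotoxicity, with a stated time of 48 h (a higher number here means a weaker inhibitor, a lower number a stronger inhibitor), compound 1 gives 130 nM. Compound 2 `C=Cc1cn([C@H]2C[C@H](O)[C@@H](CO)O2)c(=O)[nH]c1=O` carries a vinyl group, and in this assay compound 2 gives 14200 nM, which is a 110-fold higher number from compound 1 to compound 2 (2.04 log units; beyond the scatter). Compound 3 `CS(=O)(=O)Cc1cn([C@H]2C[C@H](O)[C@@H](CO)O2)c(=O)[nH]c1=O` carries a (methylsulfonyl)methyl group, and in this assay compound 3 reaches only a limit, > 200000 nM, which is the limit of > 200000 nM in this assay, at which 1 of the 3 values shown sits. Against compound 1 this is an at least 1500-fold higher number from compound 1 to compound 3 (3.18 log units; beyond the scatter), and against compound 2 it is an at least 14-fold higher number from compound 2 to compound 3 (1.14 log units; beyond the scatter), so compound 3 stands as the weakest of the three on the numbers shown.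

Compound 4 `C=CC#Cc1cn([C@H]2C[C@H](O)[C@@H](CO)O2)c(=O)[nH]c1=O` is not yet measured. a group of 4 heavy atoms (4 carbon; no ring) in place of a group of 5 heavy atoms (2 carbon, 2 oxygen, 1 sulfur; no ring), on an aromatic carbon The entering group, like the vinyl of compound 2, is built of carbon only. The step that bears most directly is an at least 14-fold higher number from compound 2 to compound 3 (1.14 log units; beyond the scatter), where (methylsulfonyl)methyl in place of vinyl raised the number sharply. Going the other way, a carbon-only group in place of (methylsulfonyl)methyl is expected to lower the number, and compound 4 is expected to land near compound 2 rather than near compound 1, since a 110-fold higher number from compound 1 to compound 2 (2.04 log units; beyond the scatter) places the vinyl far from the nitro. Compound 4 is therefore estimated at 10000 nM, between 2000 nM and 100000 nM, an expected step of an at least 20-fold lower number from compound 3 to compound 4 (1.30 log units; beyond the scatter).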

Compound 4, half-maximal inhibitory concentration: > 200000 nM
Compound 4: a limit, no number; the forecaster's own chance of this, stated with the estimate: 15%; middle value at least 20-fold (1.30 log units) from the limit.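

The group of compound 4 and the vinyl of compound 2 are both built of carbon only, yet this assay gives an at least 14-fold higher number from compound 2 to compound 4 (1.14 log units; beyond the scatter), so a carbon-only group on this aromatic carbon does not by itself keep the number low. The gap to the nitro group is wider still, with an at least 1500-fold higher number from compound 1 to compound 4 (3.18 log units; beyond the scatter), which leaves the nitro of compound 1 well apart from every other group shown. The step between compound 3 and compound 4 cannot be read, since each compound sits at a limit and not at a number: the limit of > 200000 nM in this assay, at which 2 of the 4 values shown sit.

The compounds shown leave open whether the rise from compound 2 to compound 4 follows the longer carbon chain or the triple bond in it, and a plain ethyl or ethynyl group on the same carbon would bear on that. They also leave open whether anything else here comes close to the nitro group, for instance a nitrile or a halogen such as bromine, and how far past the limit compound 3 and compound 4 really lie.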